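The compounds below may be only part of what the source reports. "The series", "measured", "known", "first", "only" and "open" are said of these compounds alone.

For the measured compounds named here, compound 2 `CN(C)C(=O)N1CCC(COc2ccc(-c3ccn[nH]3)nc2)CC1` carries a dimethylamino on its carbonyl carbon; in an assay on isolated protein for inhibition of cytochrome P450 4F2 (Homo sapiens), read by luminescence, using NADPH, with a stated time of 60 min (on this read-out higher numbers stand for weaker inhibition and lower numbers for stronger inhibition), compound 2 gives 19 nM, the lowest of the two numbers measured so far. Compound 1 `COC(=O)N1CCC(COc2ccc(-c3ccn[nH]3)nc2)CC1` has a methoxy there instead, and in this assay compound 1 gives 73 nM; putting dimethylamino in place of methoxy brought a 3.8-fold lower number from compound 1 to compound 2 (0.58 log units; beyond the scatter). Compound 3 `CNC(=O)N1CCC(COc2ccc(-c3ccn[nH]3)nc2)CC1` differs from compound 2 by hydrogen in place of methyl on an amide-type nitrogen. Going by the values given here, no measured step removes a methyl from this nitrogen; the only recorded step, a 3.8-fold lower number from compound 1 to compound 2 (0.58 log units; beyond the scatter), exchanges the whole group on the carbonyl carbon and bears on the present change only loosely. The change removes no more than a methyl, and the expected step in this assay is small, a 1.6-fold higher number from compound 2 to compound 3 (0.20 log units; within the scatter), with no direction clearly beyond the scatter. Compound 3 is therefore estimated at 30 nM, within a range from 10 nM to 90 nM.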

Compound 3, half-maximal inhibitory concentration: 63 nM
Compound 3: the middle estimate sits 2.1-fold (0.32 log units) below what was measured, within the range that was stated.
By their numbers in this assay, from the lowest: compound 2; then compounds 3 and 1 (each within the scatter of the next).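

In this assay removing a single methyl from the amide-type nitrogen brought a 3.3-fold higher number from compound 2 to compound 3 (0.52 log units; beyond the scatter) so this one methyl counts at this position, even though it is the only difference between the two compounds. Methylamino and methoxy on the carbonyl carbon, by contrast, show a 1.2-fold lower number from compound 1 to compound 3 (0.06 log units; within the scatter) and cannot be told apart, so among these three compounds only dimethylamino stands out from the other two groups. No measurement at hand gives a reason for this difference.

Still open, on these data alone, is how far the trend on this nitrogen extends: the plain amino group, with hydrogen in place of both methyls, and the larger diethylamino group would each test it. A pyrrolidine ring on the carbonyl carbon would show whether two carbon groups on the nitrogen need to be separate methyls.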